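Swapping the Aryl Group on the Amine Nitrogen

This account rests on a few compounds, and the source may have more. Where it says the series, first, only, none or still open, it means among the compounds named here.

Three compounds share one core and differ only in the aromatic ring attached to the amine nitrogen. Compound 1 `FC(F)(F)c1cccc(NCn2nc(-c3ccc4c(c3)OCCO4)oc2=S)c1` gives 7620 nM in a functional assay, with a stated time of 6 min; a lower number here means a stronger inhibitor, a higher number a weaker inhibitor. Compound 2 `FC(F)(F)c1cc(NCn2nc(-c3ccc4c(c3)OCCO4)oc2=S)cc(C(F)(F)F)c1` gives 9320 nM, and compound 3 `S=c1oc(-c2ccc3c(c2)OCCO3)nn1CNc1cccc(Cl)c1` gives 6220 nM. Compound 3 shows the lowest of the three values, yet the gaps are small: the change a 1.2-fold lower number from compound 1 to compound 3 (0.09 log units; within the scatter), and the values of compound 3 and compound 2 also lie within the scatter of each other.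

Compound 4 `COc1ccccc1NCn1nc(-c2ccc3c(c2)OCCO3)oc1=S` follows from compound 3 by the change (2-methoxyphenyl in place of 3-chlorophenyl on an amine nitrogen). Going by the values given here, no measured step covers this exact swap. The two steps that exist, a 1.2-fold higher number from compound 1 to compound 2 (0.09 log units; within the scatter) and a 1.2-fold lower number from compound 1 to compound 3 (0.09 log units; within the scatter), both alter substituents on this same ring and both stayed within the scatter, so no step beyond the scatter is expected here either. The expected change is a 1.0-fold higher number from compound 3 to compound 4 (0.02 log units; within the scatter). Compound 4 is therefore estimated at 6500 nM, in a range from 2500 nM to 17000 nM.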

Compound 4, half-maximal inhibitory concentration: 6300 nM
Estimate against measurement, compound 4: 1.0-fold (0.01 log units) above, and the stated range covers the measured number.
By their numbers in this assay, from the lowest: compounds 3, 4, 1 and 2 (each within the scatter of the next).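

In this assay, 2-methoxyphenyl in place of 3-chlorophenyl on the amine nitrogen gives a 1.0-fold higher number from compound 3 to compound 4 (0.01 log units; within the scatter). The earlier steps shown here exchanged only halogen-bearing groups, whereas this one removes the chlorine and brings in oxygen, and the entering group carries a hydrogen-bond acceptor that the leaving group lacks, yet the number still stays within the scatter. So at this position, a change in the kind of substituent, and not only in its size or number, has so far left the reading where it was, and no supporting measurement is available to explain this result.

Still open, as far as these compounds go, is whether a ring-borne carboxylic acid or amine would move the number beyond the scatter. The same question applies to a pyridine or cyclohexyl ring in place of the phenyl, and to a longer chain in place of the saturated chain carbon on the amine nitrogen.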